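Neopentyl for phenyl on a second core: predicted clearance

This account rests on a few compounds, and the source may have more. Where it says the series, first, only, none or still open, it means among the compounds named here.

Four compounds share a chloro-substituted benzylamide bearing a tetrazole, joined through an amide to a small saturated ring that carries a hydroxy-acyl group. Compound 1 `O=C(NCc1cc(Cl)ccc1-n1cnnn1)[C@@H]1CC=NN1C(=O)[C@H](O)c1ccccc1` and compound 2 `CC(C)(C)C[C@@H](O)C(=O)N1N=CC[C@H]1C(=O)NCc1cc(Cl)ccc1-n1cnnn1` share one core; compound 3 `O=C(NCc1cc(Cl)ccc1-n1cnnn1)[C@@H]1[C@H]2C[C@H]2CN1C(=O)[C@H](O)c1ccccc1` and compound 4 `CC(C)(C)C[C@@H](O)C(=O)N1C[C@@H]2C[C@@H]2[C@H]1C(=O)NCc1cc(Cl)ccc1-n1cnnn1` share another. The difference between the two cores is not broken down here.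

In an ADME assay on liver for metabolic stability, with Liver microsome (Homo sapiens) as the target, read by LC-MS, using microsomes (a higher number here means faster removal of the compound, a lower number slower removal), compound 1 sits at the limit of the assay, < 12 mL.min-1.g-1, which is a limit rather than a number (the limit of < 12 mL.min-1.g-1 in this assay, at which 1 of the 3 values shown sits). Compound 2 gives 22 mL.min-1.g-1. The change between them is neopentyl in place of phenyl on a saturated chain carbon bound to a carbonyl carbon and an oxygen on a saturated carbon, and it produces an at least 1.8-fold higher number from compound 1 to compound 2 (0.26 log units; that floor lies within the scatter).

Compound 3 gives 61 mL.min-1.g-1, the highest of the two numbers measured, and beyond the scatter from compound 2. Compound 4 has not been measured. It differs from compound 3 by neopentyl in place of phenyl on a saturated chain carbon bound to a carbonyl carbon and an oxygen on a saturated carbon, the same change as from compound 1 to compound 2, made at the same place on a different core.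

For compound 4 a step of a 1.8-fold higher number from compound 3 to compound 4 (0.26 log units; within the scatter) is expected, resting on the direction seen when compound 1 became compound 2, an at least 1.8-fold higher number from compound 1 to compound 2 (0.26 log units; that floor lies within the scatter), though that earlier step is only a floor. Compound 4 is therefore estimated at 110 mL.min-1.g-1, with a plausible range from 50 mL.min-1.g-1 to 250 mL.min-1.g-1, the width reflecting that one example on another core is thin ground.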

Compound 4, intrinsic clearance in microsomes: 20 mL.min-1.g-1
Estimate against measurement, compound 4: 5.5-fold (0.74 log units) above, and the stated range ends above it.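

In this assay, putting neopentyl in place of phenyl gives a 3.1-fold lower number from compound 3 to compound 4 (0.48 log units; beyond the scatter), so on this core the change goes with slower removal of the compound from the microsomes, not faster. Set beside the earlier pair, the same change at the same place does not carry from one core to the other, and even the direction of the step depends on the core it is made on: the same change on two cores in this assay, an at least 1.8-fold higher number (0.26 log units; that floor lies within the scatter) from compound 1 to compound 2 and a 3.1-fold lower number (0.48 log units; beyond the scatter) from compound 3 to compound 4, at least 5.5-fold (0.74 log units) apart, beyond the scatter of two such steps. Compound 1 gives < 12 mL.min-1.g-1, which is a limit of the assay and not a number, so the earlier step is only a floor, and these two pairs neither explain why the cores part ways nor set a rule for any further core.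

At this place the compounds shown carry only phenyl and neopentyl, so it stays open how a longer straight chain, or a chain ending in an amine or a carboxylic acid, would behave on either core. Also open, as far as these compounds go, is whether a third core would follow the first pair, the second pair or neither, and how the two cores compare with each other once the group at this place is held fixed.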